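A larger group returns to the amine of compound 2

This account rests on a few compounds, and the source may have more. Where it says the series, first, only, none or still open, it means among the compounds named here.

In a toxicity assay on A549 cells (Homo sapiens) for cytotoxicity, read by luminescence and CellTiter-Glo, with a stated time of 48 h (a lower number here means that less compound is tolerated, a higher number that more compound is tolerated), compound 2, `CCCCOc1ccc(-c2nc3ncccn3c2NCCC)cc1`, reaches only the limit > 100000 nM and gives no number. Its neighbours do give numbers: compound 1, `CCCCOc1ccc(-c2nc3ncccn3c2NC2CCCCCC2)cc1`, gives 26000 nM, and compound 3, `CCCCOc1ccc(-c2nc3ncccn3c2NC(C)C)cc1`, gives 68000 nM. The step of an at least 3.8-fold higher number from compound 1 to compound 2 (0.58 log units; beyond the scatter) and the step of a 2.6-fold higher number from compound 1 to compound 3 (0.42 log units; beyond the scatter) both run the same way, so the cycloheptyl of compound 1 is tolerated less than either propyl or isopropyl, while the step of an at least 1.4-fold lower number from compound 2 to compound 3 (0.16 log units; that floor lies within the scatter) stays within the scatter.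

Compound 4, `CCCCOc1ccc(-c2nc3ncccn3c2NCc2ccccn2)cc1`, differs from compound 2 by pyridin-2-yl in place of ethyl on a saturated chain carbon bound to a nitrogen on an aromatic ring. This change enlarges the group on the nitrogen, and in the two steps that bear on it, a larger group went with a lower number, so a lower number than the limit of compound 2 is expected, though the limit of > 100000 nM in this assay, at which 1 of the 3 values shown sits, leaves the true size of the step open. The estimated step from compound 2 to compound 4 is an at least 1.6-fold lower number from compound 2 to compound 4 (0.22 log units; that floor lies within the scatter). For compound 4 the expected value is 60000 nM, with a range from 20000 nM to 150000 nM.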

Compound 4, half-maximal cytotoxic concentration: > 100000 nM
Compound 4 gave a limit, no number; the forecaster's own chance of this, stated with the estimate: 35%; middle value at least 1.6-fold (0.22 log units) away from the limit.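

Compound 4 gives only a limit, as compound 2 does, so the step between them cannot be read, and such limits now make up much of this small set: the limit of > 100000 nM in this assay, at which 2 of the 4 values shown sit. In this assay, the other two comparisons can be read in part: the change from cycloheptyl gives an at least 3.8-fold higher number from compound 1 to compound 4 (0.58 log units; beyond the scatter), which goes beyond the scatter, while the change from isopropyl gives an at least 1.4-fold higher number from compound 3 to compound 4 (0.16 log units; that floor lies within the scatter), whose floor stays within it. A larger group on this nitrogen therefore does not by itself go with a lower number: compound 1 fits that earlier reading, and compound 4 goes against it.

Going by these compounds, how far compound 2 and compound 4 lie past their limits remains open. So does whether a benzyl group on the same nitrogen would behave like (pyridin-2-yl)methyl.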